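One More Methoxy on Compound 1

This account rests on a few compounds, and the source may have more. Where it says the series, first, only, none or still open, it means among the compounds named here.

Values in a functional assay on HaCaT cells (Homo sapiens) for antiproliferative activity, read by sulforhodamine B assay, with a stated time of 3 days; a lower number here means a stronger inhibitor, a higher number a weaker inhibitor:
- compound 1 `COC(=O)c1cc(CCc2ccccc2OC)ccc1O`: 20000 nM
- compound 2 `COC(=O)c1cc(CCc2cccc(OC)c2)ccc1O`: 37000 nM
- compound 3 `COC(=O)c1cc(CCc2cccc(OC)c2OC)ccc1O`: 33000 nM

Compound 1 carries the lowest of these three numbers, though its gaps to the other two stay within the scatter. Compound 4 `COC(=O)c1cc(CCc2ccc(OC)cc2OC)ccc1O` has not yet been measured. It differs from compound 1 by a single change: methoxy in place of hydrogen on an aromatic carbon. This is methoxy in place of hydrogen on an aromatic carbon, meta to a methoxy group and para to a large group.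

Going by the values given here, two measured steps bear on it, as each makes the same kind of change: a 1.7-fold higher number from compound 1 to compound 3 (0.22 log units; within the scatter) and a 1.1-fold lower number from compound 2 to compound 3 (0.05 log units; within the scatter). Both are small, and neither leaves the scatter. Neither puts the methoxy at the place it takes in compound 4, so the evidence is indirect. No step beyond the scatter is therefore expected in this assay, and no direction can be argued. For compound 4 the estimated value is 26000 nM, with an expected range of 13000 nM to 50000 nM. That estimate means an expected step of a 1.3-fold higher number from compound 1 to compound 4 (0.11 log units; within the scatter).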

Compound 4, half-maximal inhibitory concentration: 19000 nM
Compound 4: the middle estimate sits 1.4-fold (0.14 log units) above what was measured, and the stated range covers the measured number.
By their numbers in this assay, from the lowest: compounds 4, 1, 3 and 2 (each within the scatter of the next).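

The step at this position, meta to a methoxy group and para to a large group, can now be read directly: in this assay the added methoxy gives a 1.1-fold lower number from compound 1 to compound 4 (0.02 log units; within the scatter) and so leaves the number where compound 1 had it. Going by these compounds alone, the earlier steps placed the methoxy elsewhere, so this is the first reading of the change at this place, and it too stays inside the scatter. The change also reads alike on two cores: the same change on two cores in this assay, a 1.1-fold lower number (0.05 log units; within the scatter) from compound 2 to compound 3 and a 1.1-fold lower number (0.02 log units; within the scatter) from compound 1 to compound 4, 1.1-fold (0.03 log units) apart, within the scatter of two such steps.

The compounds shown carry only methoxy or hydrogen here, so they leave open whether another group at this position, such as an amine or a carboxylic acid, would move the number beyond the scatter. With every step inside the scatter, they also give no direction for methoxy at any of the places shown.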